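This account rests on a few compounds, and the source may have more. Where it says the series, first, only, none or still open, it means among the compounds named here.

Compound 1 `Cn1nc(-c2nnc(-c3ccccc3)o2)c2ccccc21`: 84600 nM
Compound 2 `Cn1nc(-c2nnc(-c3ccccc3Br)o2)c2ccccc21`: 89000 nM

Both numbers come from an ADME assay on L02 cells (Homo sapiens) for cytotoxicity, read by MTT assay, with a stated time of 72 h; on this read-out lower numbers stand for stronger inhibition and higher numbers for weaker inhibition. For the measured compounds named here, compound 2 is one of only two measured compounds; its sole neighbour is compound 1, and the step of a 1.1-fold higher number from compound 1 to compound 2 (0.02 log units; within the scatter) lies within the scatter, so the two cannot be told apart on this read-out.

Compound 3 `Cn1nc(-c2nnc(-c3ccc(Cl)cc3)o2)c2ccccc21` has not yet been measured. It differs from compound 2 by 4-chlorophenyl in place of 2-bromophenyl on an aromatic carbon. Going by the values given here, the one measured step that bears on it, a 1.1-fold higher number from compound 1 to compound 2 (0.02 log units; within the scatter), shows that adding bromo to the phenyl ring changed nothing beyond the scatter. Among the compounds with values here, no measured compound carries 4-chlorophenyl, so the effect of that group is untested. Taking the small step from compound 1 to compound 2 as the only guide, compound 3 is expected to sit close to compound 2, with a 1.0-fold lower number from compound 2 to compound 3 (0.02 log units; within the scatter). The estimate for compound 3 in this assay is 85000 nM, with a range from 40000 nM to 180000 nM.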

Compound 3, half-maximal inhibitory concentration: > 100000 nM
Compound 3: a limit, no number; the forecaster's own chance of this, stated with the estimate: 25%; middle value at least 1.1-fold (0.07 log units) away from the limit.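

The result for compound 3 in this assay is a limit, not a number: the limit of > 100000 nM in this assay, at which 1 of the 3 values shown sits. Replacing 2-bromophenyl with 4-chlorophenyl gives an at least 1.1-fold higher number from compound 2 to compound 3 (0.05 log units; that floor lies within the scatter), and putting chloro in place of hydrogen gives an at least 1.1-fold higher number from compound 1 to compound 3 (0.07 log units; that floor lies within the scatter), so neither step, read at its floor, separates the compounds. What the earlier pair did not show is that 4-chlorophenyl, a different halogen-bearing ring from 2-bromophenyl, also brings no move towards stronger inhibition on this read-out.

On these data alone, how far the true value of compound 3 lies beyond its limit stays open, and so does the real size of both steps. Also open, as far as these compounds go, is whether an amine or a carboxylic acid on the phenyl ring would shift the number beyond the scatter.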